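A few compounds are considered here, and "the series" means these few. Any claim that something is new, unique, unknown or untested is made for them only; others in the source may bear on it.

Compounds measured so far:
compound 1, `CC1CCN(C2CCN(S(=O)(=O)c3cccc(Cl)c3)CC2)CC1`; compound 2, `CC1CCN(C2CCN(S(=O)(=O)c3cccc(-c4ccc(F)cc4)c3)CC2)CC1`; compound 3, `CC1CCN(C2CCN(S(=O)(=O)c3cccc(-c4ccccc4)c3)CC2)CC1`. Compound 4, `Cc1ccc(-c2cccc(S(=O)(=O)N3CCC(N4CCC(C)CC4)CC3)c2)cc1`, is not yet measured.

In a functional assay on DLD-1 cells (Homo sapiens) for antiproliferative activity, read by CellTiter-Glo, with a stated time of 72 h (on this read-out higher numbers stand for weaker inhibition and lower numbers for stronger inhibition), compound 1 gives only a limit of the assay, > 5000 nM (the limit of > 5000 nM in this assay, at which 1 of the 3 values shown sits). In this assay compound 2 gives 12 nM and compound 3 gives 2 nM, the lowest of the two numbers shown. The steps of an at least 410-fold lower number from compound 1 to compound 2 (2.61 log units; beyond the scatter) and an at least 2500-fold lower number from compound 1 to compound 3 (3.39 log units; beyond the scatter) are large. The step of a 6.0-fold lower number from compound 2 to compound 3 (0.78 log units; beyond the scatter) is modest and is the one that bears on the change at hand, (methyl in place of hydrogen on an aromatic carbon), since both alter the same position of the outer ring. A small loss or no change beyond the scatter is expected for compound 4, a 2.5-fold higher number from compound 3 to compound 4 (0.40 log units; beyond the scatter). The estimate for compound 4 in this assay is 5 nM, in the range 1.5 nM to 20 nM.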

Compound 4, half-maximal inhibitory concentration: 11 nM
Compound 4: the middle estimate sits 2.2-fold (0.34 log units) below what was measured, and the stated range covers the measured number.
By their numbers in this assay, from the lowest: compound 3; then compounds 4 and 2 (each within the scatter of the next). At a limit, above all of these: compound 1.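

In this assay, methyl at this position of the outer ring does not match the unsubstituted phenyl: a 5.5-fold higher number from compound 3 to compound 4 (0.74 log units; beyond the scatter). Methyl and fluoro here cannot be told apart, a 1.1-fold lower number from compound 2 to compound 4 (0.04 log units; within the scatter), so compound 3 remains the only one of the three biaryl compounds clearly separated from the others. The step of an at least 450-fold lower number from compound 1 to compound 4 (2.65 log units; beyond the scatter) is reckoned against a limit of the assay, the one for compound 1: the limit of > 5000 nM in this assay, at which 1 of the 4 values shown sits.

Open, as far as these compounds go, is whether a methoxy group, an amine or a longer chain at this position would also give a higher number than compound 3. Also open, from the compounds shown here alone, is whether any group here gives a lower one.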